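A few compounds are considered here, and "the series" means these few. Any claim that something is new, unique, unknown or untested is made for them only; others in the source may bear on it.

Of the compounds shown here, two have been read in an ADME assay on HaCaT cells (Homo sapiens) for cytotoxicity, read by MTT assay, with a stated time of 72 h (on this read-out higher numbers stand for weaker inhibition and lower numbers for stronger inhibition), so far. Compound 1 `Cc1cc(-c2ccccc2)n(/C(N)=N/S(=O)(=O)c2cc(C)c(Cl)cc2SCc2cccc3ccccc23)n1` gives 12000 nM there; compound 2 `Cc1cc(S(=O)(=O)/N=C(\N)n2nccc2-c2ccccc2)c(SCc2ccccc2)cc1Cl` gives 18000 nM, and the two numbers lie within the usual scatter of each other, so neither can be ranked above the other. Compound 3 `Cc1cc(-c2ccccc2)n(/C(N)=N/S(=O)(=O)c2cc(C)c(Cl)cc2SCc2ccc(C(F)(F)F)cc2)n1` is not yet measured. It differs from compound 1 by 4-(trifluoromethyl)phenyl in place of naphthalen-1-yl on a saturated chain carbon bound to a sulfur. Among the measured compounds shown here, no measured pair carries a change of this kind, so no shift beyond the scatter is expected in this assay. The expected step is no change at the digits printed from compound 1 to compound 3 (within the scatter). Compound 3 is accordingly estimated at 12000 nM, with a range from 6000 nM to 25000 nM.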

Compound 3, half-maximal inhibitory concentration: 18000 nM
Beside the measured number, compound 3's estimate is 1.5-fold (0.18 log units) below it; measured number inside the range.
By their numbers in this assay, from the lowest: compounds 1, 2 and 3 (each within the scatter of the next).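

In this assay, among the compounds shown here, replacing naphthalen-1-yl with 4-(trifluoromethyl)phenyl on a saturated chain carbon bound to a sulfur gives a 1.5-fold higher number from compound 1 to compound 3 (0.18 log units; within the scatter) and is the only one-place change that can be read. At this position, going from two aromatic rings of carbon to one at an equal heavy-atom count leaves the number within the scatter. No measured evidence on this result is available to explain it. Still open, going by these compounds, is how this position responds to a different kind of group, such as a carboxylic acid or an amine on the benzyl ring. A one-place change elsewhere on the core also remains to be read.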